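The compounds below may be only part of what the source reports. "The series", "measured", "known", "first", "only" and "open" are said of these compounds alone.

Compound 1 `NC(=O)c1c(NC(=O)c2ccccc2Cl)sc2c1CCN(Cc1ccccc1Cl)C2`: 4430 nM
Compound 2 `NC(=O)c1c(NC(=O)c2ccc(C(F)(F)F)cc2)sc2c1CCN(Cc1ccc(Cl)cc1Cl)C2`: 10900 nM
Compound 3 `Cc1ccc(C(=O)Nc2sc3c(c2C(N)=O)CCN(Cc2ccc(Cl)cc2Cl)C3)cc1`: 25500 nM

In a functional assay on MKN-74 cells (Homo sapiens) for antiproliferative activity, with a stated time of 24 h (on this read-out higher numbers stand for weaker inhibition and lower numbers for stronger inhibition), compound 1 gives the lowest of the three numbers; compound 2 lies nearest with 10900 nM and compound 3 furthest with 25500 nM. Compound 4 `NC(=O)c1c(NC(=O)c2ccccc2Cl)sc2c1CCN(C(=S)Nc1ccccc1Br)C2` has not yet been measured. It differs from compound 1 in one place: a group of 10 heavy atoms (7 carbon, 1 nitrogen, 1 sulfur, 1 bromine; one six-membered aromatic ring of carbon only) in place of a group of 8 heavy atoms (7 carbon, 1 chlorine; one six-membered aromatic ring of carbon only), on an amine nitrogen in a ring. Within the data shown here, the only measured step, a 2.3-fold higher number from compound 2 to compound 3 (0.37 log units; beyond the scatter), concerns a substituent on the aromatic ring of the amide and not the ring amine nitrogen, so no measured step bears directly on this change, and the direction cannot be read from the data. For compound 4 the expected step is a 1.4-fold higher number from compound 1 to compound 4 (0.13 log units; within the scatter), small and uncertain. The estimate for compound 4 is 6000 nM, expected to lie between 1500 nM and 25000 nM.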

Compound 4, half-maximal inhibitory concentration: 10800 nM
Compound 4: middle estimate off by 1.8-fold (0.26 log units), on the low side, and the stated range covers the measured number.
By their numbers in this assay, from the lowest: compound 1; then compounds 4 and 2 (each within the scatter of the next); then compound 3.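

Among the compounds shown, this is the only step at the amine nitrogen in the ring. In this assay, it gives a 2.4-fold higher number from compound 1 to compound 4 (0.39 log units; beyond the scatter), a modest change for replacing 2-chlorobenzyl with a larger group that carries a hydrogen-bond donor and acceptor. No measurement at hand bears on why the number rises. On these data alone, the step exchanges the halogen and the linking atoms together, and the share of each remains open. Also open, as far as these compounds go, is how an unsubstituted benzyl group or a urea on that nitrogen would compare.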